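The source may hold more compounds than are shown below. What is called first, only, known or untested is meant among the compounds shown, and "the series" means these compounds.

Measured so far:
- compound 1 `COc1ccc(Nc2ccnc(NCCNc3ccnc4cc(Cl)ccc34)n2)cc1`: "not active" (no number reported)
- compound 2 `Clc1ccc2c(NCCCNc3nccc(Nc4ccc(Br)cc4)n3)ccnc2c1`: 11200 nM
- compound 3 `Fc1ccc(Nc2ccnc(NCCCCNc3ccnc4cc(Cl)ccc34)n2)cc1`: "not active" (no number reported)

In an ADME assay on Vero cells (Chlorocebus sabaeus) for cytotoxicity, read by neutral red uptake, with a stated time of 72 h (on this read-out lower numbers stand for stronger inhibition and higher numbers for weaker inhibition), compound 3 gives "not active" (no number reported), so no single number places it on the scale. One further entry is the same: compound 1 gives "not active" (no number reported). Only compound 2 supplies a number, at 11200 nM. Compound 4 `Clc1ccc2c(NCCCCNc3nccc(Nc4ccc(Br)cc4)n3)ccnc2c1` is not yet measured. The change from compound 3 to compound 4 is bromo in place of fluoro on an aromatic carbon. Among the measured compounds shown here, no measured pair sharing this change exists in this assay, so no step size can be read from the data; the expectation is a move from an unreported entry to a reportable concentration, of uncertain size. For compound 4 the expected half-maximal inhibitory concentration is estimated at 15000 nM, with a range from 6000 nM to 40000 nM, and a real chance that only a limit is reported again.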

Compound 4, half-maximal inhibitory concentration: 10000 nM
For compound 4 the middle estimate is 1.5-fold (0.18 log units) above the measured one; low and high end bracket the measured number.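

In this assay no step can be read from compound 3 to compound 4: compound 4 gives 10000 nM while compound 3 has no number. The compounds shown leave open what size of change 4-fluorophenyl to 4-bromophenyl brings on this read-out. No supporting evidence bears on this result.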